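The compounds below may be only part of what the source reports. "The series", "measured", "known", "first", "only" and "open" are said of these compounds alone.

In an assay on Sf9 cells for inhibition of protein deacetylase HDAC6 (Homo sapiens), read by fluorescence, with a stated time of 40 min, tested at 100 nM (on this read-out lower numbers stand for less inhibition and higher numbers for more inhibition at the one concentration tested (going by the name of the read-out)), the measured compounds stand as follows:
compound 1, `O=C(NO)c1ccc(NCc2nc(-c3ccc(Br)o3)nn2-c2ccccc2)cc1`, 55.8%
compound 2, `O=C(NO)c1ccc(NCc2nc(-c3ccccc3)nn2-c2ccc(Br)cc2)cc1`, 65.9%
compound 3, `Nc1ccccc1NC(=O)c1ccc(NCc2nc(-c3ccccc3)nn2-c2ccccc2)cc1`, 5%

Among these three numbers compound 1 stands second highest. Its nearest neighbour, compound 2, lies higher by an amount beyond the usual scatter; compound 3, the furthest, lies far lower, also beyond the scatter. Compound 4, `Cc1ccc(-c2nc(CNc3ccc(C(=O)NO)cc3)n(-c3ccccc3)n2)s1`, is not yet measured. It differs from compound 1 in one place: 5-methylthiophen-2-yl in place of 5-bromofuran-2-yl on an aromatic carbon. Within the data shown here, no step between two measured compounds shows what such a swap does, so the expectation rests on compound 1 alone. Because compound 1 gives 55.8% and the change keeps one five-membered aromatic ring with 1 hetero atom, compound 4 is expected to sit close by, with an expected step of a number 0.8 percentage points lower from compound 1 to compound 4 (within the scatter) staying within the scatter. The estimate for compound 4 is 55%, within 35% to 75%.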

Compound 4, a percentage reported as inhibition, at one concentration (the size of the read-out at that concentration, not a potency): 79.7%
Beside the measured number, compound 4's estimate is 24.7 percentage points below it, outside the stated range (above it).
By their numbers in this assay, from the lowest: compound 3; then compound 1; then compound 2; then compound 4.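

At this position, an aromatic carbon between two ring nitrogen atoms, the swap gives a number 23.9 percentage points higher from compound 1 to compound 4 (beyond the scatter) in this assay. Both groups have the same count of heavy atoms and one five-membered aromatic ring with 1 hetero atom, yet the read-out still moves, so these shared counts do not settle the result here. No measured property is available to explain this rise.

The swap changes the ring hetero atom and the outer substituent together, leaving open which change carries the step. As far as these compounds go, how an amine or a carboxylic acid in place of the methyl would fare also remains open.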